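The compounds below may be only part of what the source reports. "The series", "measured", "known", "first", "only" and "open" are said of these compounds alone.

Compound 1 `CC(C)(C)N(NC(=O)c1ccccc1)C(=O)c1ccc(Cl)cc1Cl` and compound 2 `Cc1cccc(C(=O)NN(C(=O)c2ccccc2Cl)C(C)(C)C)c1` share a core and are both measured in an assay on cells for agonist activity at ecdysone receptor (Bombyx mori), read by a luciferase reporter, with a stated time of 24 h; a lower number here means that less compound is needed, a higher number that more compound is needed for the effect. In this assay compound 1 gives 117 nM, while compound 2 gives 603 nM, the higher of the two numbers and a gap that lies beyond the usual scatter. Compound 3 `Cc1ccc(C(=O)NN(C(=O)c2ccccc2Cl)C(C)(C)C)cc1C` is not yet measured. Against compound 2 the difference is methyl in place of hydrogen on an aromatic carbon, which read one bond further out is 3-methylphenyl to 3,4-dimethylphenyl. With no measured step of this kind in the series, the expected step from compound 2 to compound 3 is a 1.5-fold lower number from compound 2 to compound 3 (0.18 log units; within the scatter), small and within the scatter. Compound 3 is therefore estimated at 400 nM, with a range from 150 nM to 1500 nM.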

Compound 3, half-maximal effective concentration: 87.1 nM
Estimate against measurement, compound 3: 4.6-fold (0.66 log units) above, outside the stated range (below it).
By their numbers in this assay, from the lowest: compounds 3 and 1 (each within the scatter of the next); then compound 2.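

Methyl on the aromatic carbon para to a large group and ortho to a methyl group, which turns 3-methylphenyl into 3,4-dimethylphenyl, gives the first single-place step in the series. The step in this assay is a 6.9-fold lower number from compound 2 to compound 3 (0.84 log units; beyond the scatter) and shows that this position responds to one added methyl beyond the scatter. Nothing at hand explains the size of this step.

On these data alone, whether the lower number is specific to methyl stays open, as chloro, methoxy or ethyl on this carbon would show. Also open, as far as these compounds go, is whether the added methyl has the same effect without the methyl already on the ring.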